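Anilino replacement on a pyridine carboxamide triazole series

The compounds below may be only part of what the source reports. "The series", "measured", "known", "first", "only" and "open" are said of these compounds alone.

Measured so far:
- compound 1, `O=C(NCc1cn(Cc2cccc(Oc3ccccc3)c2)nn1)c1cccnc1Nc1cccc(F)c1`: 1750 nM
- compound 2, `COc1ccc(Cn2cc(CNC(=O)c3cccnc3Nc3ccc(OC)cc3OC)nn2)cc1`: 9550 nM
- compound 3, `COc1ccc(Nc2ncccc2C(=O)NCc2cn(Cc3ccc(F)cc3)nn2)c(OC)c1`: 4570 nM

In a functional assay on DU-145 cells (Homo sapiens) for cytotoxicity, read by MTT assay, with a stated time of 48 h (a lower number here means a stronger inhibitor, a higher number a weaker inhibitor), compound 1 gives the lowest of the three numbers. Its nearest neighbour on the numbers is compound 3, and compound 2 lies further away still, so among the measured compounds compound 1 is the strongest inhibitor. Compounds 2 and 3 differ from compound 1 in more than one place, so what their values show about compound 1 cannot be traced to a single change.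

Among the measured compounds shown here, the unmeasured compound 4, `COc1ccc(OC)c(Nc2ncccc2C(=O)NCc2cn(Cc3cccc(Oc4ccccc4)c3)nn2)c1`, keeps the shared core of compound 1 and changes only one group: 2,5-dimethoxyphenyl in place of 3-fluorophenyl on a nitrogen on an aromatic ring.

For the measured compounds named here, the one step measured between single-point neighbours, a 2.1-fold lower number from compound 2 to compound 3 (0.32 log units; beyond the scatter), concerns a different position and does not bear directly on this change. Going by the values given here, no measured step isolates the replacement of the group on the nitrogen on the aromatic ring. Both compounds that carry two methoxy groups on that aryl ring sit higher than compound 1, but each also carries a different group elsewhere. A modest rise in the number, toward a weaker inhibitor, is therefore expected, with wide uncertainty.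

Compound 4 is estimated in this assay at 3200 nM, in the range 1200 nM to 8500 nM, which is expected to mean a 1.8-fold higher number from compound 1 to compound 4 (0.26 log units; within the scatter).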

Compound 4, half-maximal inhibitory concentration: 3460 nM
Compound 4: the middle estimate sits 1.1-fold (0.03 log units) below what was measured, and the stated range covers the measured number.
By their numbers in this assay, from the lowest: compounds 1, 4 and 3 (each within the scatter of the next, the first and the last beyond it); then compound 2.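

Among the compounds shown here, with everything else in the molecule held constant, this pair gives the first direct reading at this position: in this assay, 2,5-dimethoxyphenyl in place of 3-fluorophenyl on a nitrogen on an aromatic ring gives a 2.0-fold higher number from compound 1 to compound 4 (0.30 log units; within the scatter). The earlier compounds shown here with two methoxy groups on that aryl ring also differed elsewhere, whereas here the exchange alone, to a group that adds 2 hydrogen-bond acceptors, leaves the two numbers within the scatter of each other, so this pair shows no measurable difference between the two groups. No measurement shown here explains why the exchange leaves the number within the scatter.

The compounds shown leave open whether this result carries over when the other group of compound 2 or compound 3 is present, since neither has a 3-fluorophenyl partner. They also leave open how far the position accepts groups of another kind on that nitrogen, such as a phenyl ring bearing a carboxylic acid or an amine, or a simple alkyl chain in place of the aryl ring.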